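The compounds below may be only part of what the source reports. "The series", "measured", "known", "first", "only" and "open" are said of these compounds alone.

Measured in a functional assay on HCT-116 cells (Homo sapiens) for inhibition, read by colorimetric assay, with a stated time of 3 days; on this read-out higher numbers stand for weaker inhibition and lower numbers for stronger inhibition:

compound 1, `NC(=O)C(=O)NCCCCCCCC(=O)Nc1ccccc1`, gives > 100000 nM, which is a limit of the assay and not a number.
compound 2, `O=C(CCCCNC(=O)C(O)(O)C(F)(F)F)Nc1ccccc1`, gives 20300 nM.
compound 3, `NC(=O)C(=O)NCCCCC(=O)Nc1ccccc1`, gives > 100000 nM, again a limit of the assay.

Compound 4, `O=C(CCCCCCCNC(=O)C(O)(O)C(F)(F)F)Nc1ccccc1`, has not yet been measured. It relates to compound 1 as compound 2 relates to compound 3. The change from compound 1 to compound 4 is 2,2,2-trifluoro-1,1-dihydroxyethyl in place of carbamoyl on a carbonyl carbon, and the change from compound 3 to compound 2 is 2,2,2-trifluoro-1,1-dihydroxyethyl in place of carbamoyl on a carbonyl carbon, the same change, which gave an at least 4.9-fold lower number from compound 3 to compound 2 (0.69 log units; beyond the scatter). The difference between the two cores is not broken down here. Compound 1 sits at the limit of > 100000 nM in this assay, at which 2 of the 3 values shown sit. Because the measured step is an at least 4.9-fold lower number from compound 3 to compound 2 (0.69 log units; beyond the scatter), a step of similar size is expected here, an at least 4.0-fold lower number from compound 1 to compound 4 (0.60 log units; beyond the scatter). Compound 4 is therefore estimated at 25000 nM, and is expected to fall between 8000 nM and 80000 nM.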

Compound 4, half-maximal inhibitory concentration: 41700 nM
The estimate for compound 4 lay 1.7-fold (0.22 log units) below the measured number; the measured number falls inside the stated range.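

In this assay, putting 2,2,2-trifluoro-1,1-dihydroxyethyl in place of carbamoyl on a carbonyl carbon again lowers the number on a second core, with an at least 2.3-fold lower number from compound 1 to compound 4 (0.37 log units; beyond the scatter). Set side by side, the two steps read: the same change on two cores in this assay, an at least 4.9-fold lower number (0.69 log units; beyond the scatter) from compound 3 to compound 2 and an at least 2.3-fold lower number (0.37 log units; beyond the scatter) from compound 1 to compound 4; the limit leaves it open whether they differ. The direction of the change therefore holds on both cores, but its size cannot be compared, since each step starts from a value that is a limit and not a number: the limit of > 100000 nM in this assay, at which 2 of the 4 values shown sit.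

The compounds shown leave open how a carboxylic acid or an amine in the same place would read in this assay. They also leave open whether the change would carry over to a core with a shorter chain.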